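Aromatic-nitrogen substituent and growth inhibition: outlook for compound 3

A few compounds are considered here, and "the series" means these few. Any claim that something is new, unique, unknown or untested is made for them only; others in the source may bear on it.

Measured so far:
compound 1, `CCC(C)n1cnc2c(NCc3ccc(C(=O)Nc4ccccc4N)cc3)nc(Cl)nc21` — 65%
compound 2, `Nc1ccccc1NC(=O)c1ccc(CNc2nc(Cl)nc3c2ncn3Cc2ccccc2)cc1` — 5.32%

In a functional assay on HepG2 cells (Homo sapiens) for antiproliferative activity, read by CCK-8 assay, with a stated time of 72 h, tested at 8 uM (a higher number here means a stronger effect of the compound at the concentration tested, a lower number a weaker effect), compound 1 gives 65% and compound 2 gives 5.32%. Among the measured compounds shown here, the one measured step, a number 59.7 percentage points lower from compound 1 to compound 2 (beyond the scatter), is large, so compound 2 stands lowest of the two numbers, with compound 1 the nearest and far above it.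

Compound 3 is `CCCn1cnc2c(NCc3ccc(C(=O)Nc4ccccc4N)cc3)nc(Cl)nc21`. Its difference from compound 2 is ethyl in place of phenyl on a saturated chain carbon bound to an aromatic nitrogen. For the measured compounds named here, the only step that bears on this is a number 59.7 percentage points lower from compound 1 to compound 2 (beyond the scatter), which exchanged sec-butyl for benzyl on the same aromatic nitrogen and cost most of the effect; compound 3 undoes the aromatic part of that change and returns to a short chain on that nitrogen, though not the same chain as in compound 1. A rise well beyond the scatter is therefore expected, a number 44.7 percentage points higher from compound 2 to compound 3 (beyond the scatter), landing somewhat short of compound 1.

For compound 3 in this assay the estimate is 50%, with a range of 25% to 70%.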

Compound 3, a percentage reported as inhibition, at one concentration (the size of the read-out at that concentration, not a potency): 14.1%
Beside the measured number, compound 3's estimate is 35.9 percentage points above it, outside the stated range (below it).
By their numbers in this assay, from the lowest: compounds 2 and 3 (each within the scatter of the next); then compound 1.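

In this assay, exchanging phenyl for ethyl on a saturated chain carbon bound to an aromatic nitrogen gives a number 8.8 percentage points higher from compound 2 to compound 3 (within the scatter), so among these compounds, losing the aromatic ring of the benzyl group does not by itself restore the effect seen with sec-butyl. The large difference instead appears with a single methyl on a saturated chain carbon bound to an aromatic nitrogen and a saturated chain carbon: hydrogen in its place gives a number 50.9 percentage points lower from compound 1 to compound 3 (beyond the scatter), and the unbranched propyl of compound 3 reads with the benzyl of compound 2 rather than with the sec-butyl of compound 1. No available evidence accounts for this difference.

Three substituents cannot show whether the effect follows branching generally or is particular to sec-butyl. Going by these compounds, an isopropyl group, a cyclopentyl group and a longer unbranched chain on the same nitrogen remain open.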